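Chloro for Bromo in a Growth Inhibition Series

The compounds below may be only part of what the source reports. "The series", "measured", "known", "first", "only" and "open" are said of these compounds alone.

In a functional assay on DU-145 cells (Homo sapiens) for inhibition, read by trypan blue exclusion, with a stated time of 96 h (on this read-out higher numbers stand for weaker inhibition of growth and lower numbers for stronger inhibition of growth), compound 3 `Cc1ccc(S/C(=C/c2c[nH]c3ccc(Br)cc23)C(=O)c2ccc(Br)cc2)cc1` gives 1000 nM, level with compound 1 `Cc1ccc(CS/C(=C/c2c[nH]c3ccc(Br)cc23)C(=O)c2ccc(Cl)cc2)cc1` at 1000 nM. Together they hold the lowest of the three numbers, while compound 2 `O=C(/C(=C\c1c[nH]c2ccc(Br)cc12)SCc1ccc(Cl)cc1Cl)c1ccc(Cl)cc1` gives 10000 nM. Compound 4 `Cc1ccc(S/C(=C/c2c[nH]c3ccc(Br)cc23)C(=O)c2ccc(Cl)cc2)cc1` has chloro in place of bromo on an aromatic carbon, para to a large group: chloro in place of bromo on an aromatic carbon. For the measured compounds named here, the only measured step, a 10-fold higher number from compound 1 to compound 2 (1.00 log units; beyond the scatter), swaps 4-methylphenyl for 2,4-dichlorophenyl at another place, so it offers no direct guide. No step beyond the scatter is therefore expected in this assay. The expected change is no change at the digits printed from compound 3 to compound 4 (within the scatter). For compound 4 the estimated value is 1000 nM, with an expected range of 350 nM to 3000 nM.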

Compound 4, concentration for 50% growth inhibition: 1000 nM
For compound 4 middle estimate and measured number coincide at the digits printed, and the stated range covers the measured number.
By their numbers in this assay, from the lowest: compounds 1, 3 and 4 (each within the scatter of the next); then compound 2.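

In this assay, for the compounds shown here, chloro in place of bromo on an aromatic carbon, para to a large group, gives no change at the digits printed from compound 3 to compound 4 (within the scatter) as the first direct reading at this position. On the sulfur, 4-methylphenyl in place of 4-methylbenzyl gives no change at the digits printed from compound 1 to compound 4 (within the scatter) and 4-methylphenyl in place of 2,4-dichlorobenzyl gives a 10-fold lower number from compound 2 to compound 4 (1.00 log units; beyond the scatter) in the same series. Among these compounds, only the step involving the 2,4-dichlorobenzyl group lies beyond the scatter. As far as these compounds go, whether a methoxy group, an amine or a carboxylic acid at this position would stay level with compound 3 remains open. Nothing available explains these results.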